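The source may report more compounds than this note shows. Statements on the series, on what has been measured and on what is new or still open speak of the compounds shown alone.

Compound 1 `COc1ccc([C@H]2CC(=O)N(c3cccc(NCc4ccoc4)c3)C2)cc1OC1CCCC1`: > 10000 nM
Compound 2 `COc1ccc(OC)c(S(=O)(=O)Nc2cccc(N3C[C@@H](c4ccc(OC)c(OC5CCCC5)c4)CC3=O)c2)c1`: 7590 nM

Among the compounds with values here, in a functional assay on HEK293 cells (Homo sapiens) for cytotoxicity (on this read-out lower numbers stand for higher toxicity in this test and higher numbers for lower toxicity in this test), compound 2 gives 7590 nM, the only number among the two values shown. For compound 1 this assay reports a limit, not a number: > 10000 nM. Part of the shown values thus sits at the limit of > 10000 nM in this assay, at which 1 of the 2 values shown sits.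

Compound 3 `COc1ccc([C@H]2CC(=O)N(c3cccc(NS(=O)(=O)c4ccccc4C)c3)C2)cc1OC1CCCC1` differs from compound 2 by 2-methylphenyl in place of 2,5-dimethoxyphenyl on a sulfonyl sulfur. Within the data shown here, no step between measured compounds is available to guide this change, so the step from compound 2 to compound 3 is expected to be small, not beyond the scatter of this assay, an estimated 1.1-fold higher number from compound 2 to compound 3 (0.02 log units; within the scatter). Compound 3 is therefore estimated at 8000 nM, in a range from 3000 nM to 20000 nM.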

Compound 3, half-maximal cytotoxic concentration: > 10000 nM
Compound 3: only a limit was reported; the forecaster's own chance of this, stated with the estimate: 45%; middle value at least 1.2-fold (0.09 log units) away from the limit.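

In this assay, 2-methylphenyl in place of 2,5-dimethoxyphenyl on a sulfonyl sulfur gives an at least 1.3-fold higher number from compound 2 to compound 3 (0.11 log units; that floor lies within the scatter). The value of compound 3 is a limit, so this step is only a floor, but it shows that the group on this sulfur can carry 0 hydrogen-bond acceptors without a lower number appearing. The read-out now sits mostly at its ceiling: the limit of > 10000 nM in this assay, at which 2 of the 3 values shown sit.

The step between compound 1 and compound 3 cannot be read. Still open, as far as these compounds go, is what an amine or a carboxylic acid on this aromatic ring would give in this assay.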